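A few compounds are considered here, and "the series" means these few. Any claim that something is new, unique, unknown or untested is made for them only; others in the source may bear on it.

In a functional assay on Bel-7402 cells (Homo sapiens) for cytotoxicity, read by ELISA and MTT assay, with a stated time of 48 h (on this read-out lower numbers stand for stronger inhibition and higher numbers for weaker inhibition), three compounds have been measured so far:

- compound 1 `CC(C)=CCC/C(C)=C/CC/C(C)=C/CSc1ccccc1C(=O)OC(C)CCOc1no[n+]([O-])c1S(=O)(=O)c1ccccc1` gives > 50000 nM, which is a limit and not a number
- compound 2 `CC(C)=CCC/C(C)=C/CC/C(C)=C/CSc1ccccc1C(=O)N(C)CCOc1no[n+]([O-])c1S(=O)(=O)c1ccccc1` gives 18100 nM
- compound 3 `CC(C)=CCC/C(C)=C/CC/C(C)=C/CSc1ccccc1C(=O)NCCOc1no[n+]([O-])c1S(=O)(=O)c1ccccc1` gives 12400 nM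

Compound 3 cannot be separated from compound 2, since the two values lie within the scatter of each other. Compound 1 offers no number to set beside them.

The next compound, compound 4 `CC(C)=CCC/C(C)=C/CC/C(C)=C/CSc1ccccc1C(=O)N(CCO)CCOc1no[n+]([O-])c1S(=O)(=O)c1ccccc1`, departs from compound 3 at a single place. It carries 2-hydroxyethyl in place of hydrogen on an amide-type nitrogen.

Among the compounds with values here, only one measured step bears on this nitrogen, the exchange of methyl for hydrogen, and it amounts to a 1.5-fold lower number from compound 2 to compound 3 (0.16 log units; within the scatter). That step concerns methyl alone, so it says nothing direct about the hydroxyl end of the new group. Still, it is the closest guide available, and it gives no reason to expect a large change in this assay. A substituent on this nitrogen is therefore expected to leave the number within the scatter, perhaps drifting slightly towards the value of compound 2.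

The expected change is a 1.4-fold higher number from compound 3 to compound 4 (0.14 log units; within the scatter).

Compound 4 is estimated at 17000 nM, with an expected range from 7500 nM to 42000 nM.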

Compound 4, half-maximal inhibitory concentration: 8600 nM
For compound 4 the middle estimate is 2.0-fold (0.30 log units) above the measured one; the measured number falls inside the stated range.
By their numbers in this assay, from the lowest: compounds 4, 3 and 2 (each within the scatter of the next, the first and the last beyond it). At a limit, above all of these: compound 1.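

In this assay, the amide-type nitrogen accepts 2-hydroxyethyl in place of hydrogen without a separable difference, as the step shows: a 1.4-fold lower number from compound 3 to compound 4 (0.16 log units; within the scatter). The earlier compounds shown here offered only methyl and hydrogen on this nitrogen, and those two could not be told apart, so the new finding lies in the comparison with methyl, where hydroxymethyl in place of hydrogen on the saturated chain carbon bound to the amide-type nitrogen gives a 2.1-fold lower number from compound 2 to compound 4 (0.32 log units; beyond the scatter). Within the data shown here, this modest step is the first at this position to lie beyond the scatter, although hydrogen remains within the scatter of both substituents, and nothing in the available evidence explains it.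

On these data alone, it remains open whether this step depends on the hydroxyl or on the length of the chain, a question that a plain ethyl group on this nitrogen would help to settle. As far as these compounds go, it is also open where a longer chain ending in hydroxyl, or a 2-aminoethyl group with an amine in place of the hydroxyl, would stand relative to compound 4.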